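Flipping Two Ring Stereocentres of Compound 1

The compounds below may be only part of what the source reports. "The series", "measured", "known", "first", "only" and "open" are said of these compounds alone.

Compound 1 `C=C1CCCC(C)(C)C1CC[C@]1(C)CC[C@@H]([C@@H](C)C(=O)O)OO1` was tested in a functional assay on Malme-3M cells (Homo sapiens) for inhibition (on this read-out lower numbers stand for stronger inhibition of growth and higher numbers for weaker inhibition of growth), where compound 1 gives 3960 nM. For the measured compounds named here, that is the only actual number recorded here. Compound 2 `CC1=C(CC/C(C)=C/CC[C@@]2(C)CC[C@@H]([C@H](C)C(=O)O)OO2)C(C)(C)CCC1` is the other measured compound; in this assay compound 2 gives > 100000 nM, which is a limit of the assay rather than a number (the limit of > 100000 nM in this assay, at which 1 of the 2 values shown sits). Going by the values given here, no single-change step between the measured compounds is available, so the scale of changes remains unknown.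

Compound 3 `C=C1CCCC(C)(C)C1CC[C@@]1(C)CC[C@H]([C@@H](C)C(=O)O)OO1` has exactly the same atoms and bonds as compound 1 (the two compounds have the same atoms and bonds; at least one stereo element is drawn with a configuration in one of them and without one in the other: 2 of 4 stereo elements differ; a stereocentre at a saturated ring carbon is drawn R in compound 1 and S in compound 3; a stereocentre at a saturated ring carbon is drawn S in compound 1 and R in compound 3). Nothing measured shows what such an inversion of two ring stereocentres does, so the direction is uncertain and the step is expected to stay modest, possibly within the scatter. Compound 3 is expected to give about 6000 nM, within 1500 nM to 50000 nM, which would be an estimated step of a 1.5-fold higher number from compound 1 to compound 3 (0.18 log units; within the scatter).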

Compound 3, concentration for 50% growth inhibition: > 12500 nM
Compound 3 gave a limit, no number; the forecaster's own chance of this, stated with the estimate: 15%; middle value at least 2.0-fold (0.31 log units) from the limit.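

For the compounds shown here, compound 3 is the first comparison that changes only one thing: the same atoms and bonds, with the two ring stereocentres inverted, and in this assay this gives an at least 3.1-fold higher number from compound 1 to compound 3 (0.49 log units; beyond the scatter). So the spatial arrangement at these two ring carbons matters for growth inhibition here, which compound 1 and compound 2 could not show, as they differ in more than one place. Compound 3 gives a limit of the assay and not a number: the limit of > 12500 nM in this assay, at which 1 of the 3 values shown sits.

On these data alone, how far the inversion really moves the read-out therefore stays open, and so does whether one stereocentre alone would account for the step, since both change together here. Also open, as far as these compounds go, is whether a methyl ester in place of the carboxylic acid would respond to the same inversion.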